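The compounds below may be only part of what the source reports. "The series", "measured", "known", "first", "only" and "open" are said of these compounds alone.

Compound 3 `CCOC(=O)c1cnc(-c2cccs2)nc1NN1C(=O)C=C(C)C1=O` gives the lowest number of the three measured in a functional assay on Jurkat cells for inhibition of nuclear factor NF-kappa-B complex (Homo sapiens) (on this read-out higher numbers stand for weaker inhibition and lower numbers for stronger inhibition), with 20 nM. Compound 1 `CCOC(=O)c1cnc(C)nc1NN1C(=O)C=C(C)C1=O` gives 16000 nM, and compound 2 `CCOC(=O)c1cnc(CC)nc1NN1C(=O)C=C(C)C1=O` gives 10000 nM; the step of a 1.6-fold lower number from compound 1 to compound 2 (0.20 log units; within the scatter) is within the scatter. Compound 4 `CCOC(=O)c1cnc(-c2cc(Cl)nc(Cl)c2)nc1NN1C(=O)C=C(C)C1=O` differs from compound 3 by 2,6-dichloropyridin-4-yl in place of thiophen-2-yl on an aromatic carbon. Among the compounds with values here, no measured step exchanges one aromatic group for another at this position. Within the data shown here, the only bearing steps are an 800-fold lower number from compound 1 to compound 3 (2.90 log units; beyond the scatter) and a 500-fold lower number from compound 2 to compound 3 (2.70 log units; beyond the scatter), both large and both gained by putting an aromatic group where a small alkyl group stood. Compound 4 keeps an aromatic group at that place, so its number is expected to remain far nearer compound 3 than compounds 1 and 2, yet the two aromatic rings are not the same and a shift in either direction beyond the scatter cannot be ruled out. The estimate for compound 4 is 50 nM, with a range from 10 nM to 400 nM. The expected step for compound 4 is a 2.5-fold higher number from compound 3 to compound 4 (0.40 log units; beyond the scatter).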

Compound 4, half-maximal inhibitory concentration: 2000 nM
Compound 4: middle estimate off by 40-fold (1.60 log units), on the low side; measured number outside the range, above it.
By their numbers in this assay, from the lowest: compound 3; then compound 4; then compounds 2 and 1 (each within the scatter of the next).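

Within the data shown here, on this assay an aromatic group at this place does not by itself secure the gain: a 100-fold higher number from compound 3 to compound 4 (2.00 log units; beyond the scatter) shows that 2,6-dichloropyridin-4-yl in place of thiophen-2-yl gives up most of what the earlier steps had won. 2,6-Dichloropyridin-4-yl still improves on the small alkyl groups, with a 5.0-fold lower number from compound 2 to compound 4 (0.70 log units; beyond the scatter) and an 8.0-fold lower number from compound 1 to compound 4 (0.90 log units; beyond the scatter) as modest steps beside the large ones to compound 3, so at this position the identity of the ring counts and not only its presence. Nothing at hand explains the difference between the two rings.

On these data alone, whether the loss follows the two chlorine atoms or the change from a five-membered to a six-membered ring stays open, as this step changes both at once. A plain phenyl, an unsubstituted pyridin-4-yl or a furan-2-yl at this place would help to separate the two.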